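The source may hold more compounds than are shown below. What is called first, only, known or untested is meant among the compounds shown, and "the series" means these compounds.

Measured so far:
Compound 1 `O=C(NNc1ccccc1F)c1ccc(NS(=O)(=O)c2cnc(O)nc2O)cc1` gives 16000 nM in a functional assay on SGC-7901 cells (Homo sapiens) for antiproliferative activity, read by MTT assay, with a stated time of 24 h; a higher number here means a weaker inhibitor, a lower number a stronger inhibitor.
Compound 2 `O=C(NNc1ccc(F)cc1)c1ccc(NS(=O)(=O)c2cnc(O)nc2O)cc1` gives > 20000 nM, which is a limit of this assay.
Compound 3 `O=C(NNc1ccccc1F)c1ccccc1NS(=O)(=O)c1cnc(O)nc1O` gives > 20000 nM, which is also a limit of this assay.

Compound 4 `O=C(NNc1ccc(F)cc1)c1ccccc1NS(=O)(=O)c1cnc(O)nc1O` has not yet been measured in this assay. It differs from compound 3 by 4-fluorophenyl in place of 2-fluorophenyl on an amine nitrogen. The same change was made from compound 1 to compound 2, where it gave an at least 1.2-fold higher number from compound 1 to compound 2 (0.09 log units; that floor lies within the scatter); the place of the change reads the same in both pairs, so it is the same change. How the core of compound 3 differs from the core of compound 1 is not broken down here. A step of similar size is expected from the earlier one, a step that the limit leaves unreadable from compound 3 to compound 4, resting on that single measured step and on (the limit of > 20000 nM in this assay, at which 2 of the 3 values shown sit), since compound 3 already sits there. Compound 4 is expected to give 28000 nM, most likely as a limit again, between 16000 nM and 70000 nM.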

Compound 4, half-maximal inhibitory concentration: > 20000 nM
Compound 4: only a limit was reported; the forecaster's own chance of this, stated with the estimate: 80%; the middle value is on the limit's open side.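

The step from compound 3 to compound 4 cannot be read, because in this assay both compounds stand at a limit: the limit of > 20000 nM in this assay, at which 3 of the 4 values shown sit.

On these data alone, what 4-fluorophenyl in place of 2-fluorophenyl does on the core of compound 3 stays open.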